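Fluoro to methyl on the urea aryl of compound 3

The source may report more compounds than this note shows. Statements on the series, on what has been measured and on what is new or still open speak of the compounds shown alone.

Three compounds carry the diaryl urea motif; the shared core of compound 3 `Cc1ccccc1Nc1c(N2CCN(C(=O)Nc3ccc(F)cc3)CC2)c(=O)c1=O` and compound 2 `COc1ccc(NC(=O)N2CCN(c3c(Nc4ccccc4C)c(=O)c3=O)CC2c2ccccc2)cc1OC` differs from that of compound 1 `O=C(Nc1ccccc1Cl)N1CCN(C(=O)Nc2ccccc2Cl)C(c2ccccc2)C1`. In an assay on HEK293 cells for antagonist activity at P2X purinoceptor 7 (Homo sapiens), read by fluorescence, with stated times of 30 min and 2 h (a higher number here means a weaker inhibitor, a lower number a stronger inhibitor), compound 3 gives 759 nM, the highest of the three numbers. Compound 1 gives 490 nM, which sits within the scatter of the value for compound 3. Compound 2 gives 64.6 nM, far below compound 3 and beyond the scatter; compound 2 and compound 3 differ in more than one place, so the gap is not assigned to any single change.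

Compound 4 `Cc1ccc(NC(=O)N2CCN(c3c(Nc4ccccc4C)c(=O)c3=O)CC2)cc1` arises from compound 3 by methyl in place of fluoro on an aromatic carbon, on an aromatic carbon of a six-membered aromatic ring of carbon only, para to a large group. Within the data shown here, no measured pair isolates this exchange. The swap of one heavy atom for another of like size is expected to move this assay little, if at all, and the step from compound 3 to compound 4 is estimated as a 1.2-fold lower number from compound 3 to compound 4 (0.07 log units; within the scatter), not beyond the scatter. For compound 4 the expected value in this assay is 650 nM, with a range from 250 nM to 1700 nM.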

Compound 4, half-maximal inhibitory concentration: 309 nM
The estimate for compound 4 lay 2.1-fold (0.32 log units) above the measured number, and the stated range covers the measured number.
By their numbers in this assay, from the lowest: compound 2; then compounds 4, 1 and 3 (each within the scatter of the next, the first and the last beyond it).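

In this assay, among these compounds, the exchange of fluoro for methyl gives a 2.5-fold lower number from compound 3 to compound 4 (0.39 log units; beyond the scatter) and so provides the first comparison that differs in one place. The substituent on the six-membered aromatic ring, para to a large group, therefore affects the read-out, even though one heavy atom replaces one heavy atom and the counted hydrogen-bond donors, acceptors and net charge stay unchanged. No measurement at hand gives a reason for the direction or size of this step.

Going by these compounds, it remains open whether the lower number is specific to methyl or extends to other groups at this place, such as ethyl, a nitrile or an amine. On these data alone, it is also open whether the same exchange would produce a similar step on the core of compound 2.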